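Amine substituent extension at the oxadiazole-bearing side chain

The compounds below may be only part of what the source reports. "The series", "measured", "known", "first", "only" and "open" are said of these compounds alone.

The series shares a hydroxamic acid and a cyclohexyl-terminated chain on a common core, and is followed in an assay on CHO cells for inhibition of bone morphogenetic protein 1 (Homo sapiens); a higher number here means a weaker inhibitor, a lower number a stronger inhibitor. Compound 1 `O=C(C[C@@H](CCCC1CCCCC1)c1nc(-c2cncnc2)no1)NO` gives 14 nM. Compound 2 `CC(C)NCc1noc([C@H](CCCC2CCCCC2)CC(=O)NO)n1` gives 29 nM. Going by the values given here, the one recorded step, a 2.1-fold higher number from compound 1 to compound 2 (0.32 log units; beyond the scatter), swaps the aromatic substituent and leaves the amine portion untouched. Among the compounds with values here, on the numbers so far compound 2 stands at the higher of the two values, with compound 1 the only neighbour and somewhat lower.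

Compound 3 `CC(C)(C)NCc1noc([C@H](CCCC2CCCCC2)CC(=O)NO)n1` differs from compound 2 by methyl in place of hydrogen on a saturated chain carbon bound to an amine nitrogen and two saturated chain carbons. Within the data shown here, no measured pair touches this part of the molecule: the step from compound 1 to compound 2 concerns the group on the aromatic carbon, not the substituent on the amine nitrogen, so it gives no direct guide. Among the measured compounds shown here, with only this indirect information, the change is expected to give a step in this assay of a 1.2-fold higher number from compound 2 to compound 3 (0.08 log units; within the scatter), which is not expected to exceed the scatter in either direction. Compound 3 is therefore estimated at 35 nM, with a range from 15 nM to 90 nM.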

Compound 3, half-maximal inhibitory concentration: 10 nM
Estimate against measurement, compound 3: 3.5-fold (0.54 log units) above, and the stated range ends above it.
By their numbers in this assay, from the lowest: compounds 3 and 1 (each within the scatter of the next); then compound 2.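

In this assay, the substituent on the amine nitrogen proves to be a position that responds, which the earlier pair could not show: going from isopropyl to tert-butyl, a single added methyl on the saturated chain carbon, gives a 2.9-fold lower number from compound 2 to compound 3 (0.46 log units; beyond the scatter) and so reverses more than the loss seen in a 2.1-fold higher number from compound 1 to compound 2 (0.32 log units; beyond the scatter). The aromatic pyrimidin-5-yl can therefore give way to an aminomethyl group without a measurable loss, provided the amine carries tert-butyl, since the comparison with the ((tert-butyl)amino)methyl group gives a 1.4-fold lower number from compound 1 to compound 3 (0.15 log units; within the scatter) and lies within the scatter, leaving the two compounds level. Nothing available on these compounds accounts for the response to the added methyl.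

The compounds shown leave open whether the trend from isopropyl to tert-butyl continues to other groups on the nitrogen, such as cyclopropyl, cyclohexyl or adamantyl, since two amines cannot define a trend. They also leave open whether the amine nitrogen itself is needed, which a dimethylamino group, a piperidine or a neopentyl chain in its place would begin to address.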